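Propylamino in Place of Isopropyl(methyl)amino: An Expectation

The compounds below may be only part of what the source reports. "The series", "measured", "known", "first", "only" and "open" are said of these compounds alone.

Compound 1 `COc1cccc(Cn2cnc3c(N(C)C)ncnc32)c1` — 48%
Compound 2 `CC(C)N(C)c1ncnc2c1ncn2CC1CC1` — 32%

Of the compounds shown here, two have been measured in a functional assay on the whole organism for inhibition, with Rattus norvegicus as the target, at a dose of 25 mg/kg by the intraperitoneal route; on this read-out higher numbers stand for more inhibition at the one dose given (going by the name of the read-out) and lower numbers for less inhibition. Compound 2 stands lowest of the two numbers; its nearest neighbour is compound 1, whose number lies higher by a gap beyond the usual scatter. Among the measured compounds shown here, no single-place step joins compound 1 and compound 2, as they differ in more than one place, so nothing more than the two values themselves can be read from that pair.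

Compound 3 `CCCNc1ncnc2c1ncn2CC1CC1` has not yet been measured in this assay. Relative to compound 2 the change is propylamino in place of isopropyl(methyl)amino on an aromatic carbon. For the measured compounds named here, no measured pair isolates this exchange, so there is no step of known size to lean on, and the expectation has to rest on compound 2 alone. The expected step is a number 1 percentage points higher from compound 2 to compound 3 (within the scatter), that is, none beyond the scatter. Compound 3 is therefore estimated at 33%, with a range from 12% to 58%.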

Compound 3, a percentage reported as inhibition, in the whole organism at one dose (the size of the read-out at that dose, not a potency): 0%
Compound 3: the middle estimate sits 33 percentage points above what was measured, and the stated range ends above it.
By their numbers in this assay, from the lowest: compound 3; then compound 2; then compound 1.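

In this assay this position proves far from indifferent to the amine it carries: the exchange of isopropyl(methyl)amino for propylamino gives a number 32 percentage points lower from compound 2 to compound 3 (beyond the scatter), and compound 3 stands at 0%, the lowest of the three numbers. Among the compounds shown here, this is the first single-place step, and it shows that a small change on this aromatic carbon, next to the ring nitrogen, can separate a measurable inhibition from none at this dose. The exchange changes several things at once, going from 5 heavy atoms and 0 hydrogen-bond donors to 4 heavy atoms and 1 hydrogen-bond donor, and no measurement here explains the drop or assigns it to any one of these differences.

The compounds shown leave open whether the step goes with the hydrogen on the amine nitrogen or with the loss of the branched chain, a question that isopropylamino and methyl(propyl)amino on the same carbon would separate. They also leave open whether a longer chain such as butylamino, or a ring amine such as pyrrolidine, would keep any of the inhibition seen with compound 2.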